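Swapping the aryl piperazine substituent in a spiro-oxindole series

The compounds below may be only part of what the source reports. "The series", "measured", "known", "first", "only" and "open" are said of these compounds alone.

Measured compounds:
Compound 1, `CCC1(CCCCN2CCN(c3cccc(Cl)c3)CC2)C(=O)Nc2ccccc21`, gives 0.41 nM in an assay on CHO cells for displacement of a labelled ligand from 5-hydroxytryptamine receptor 7 (Homo sapiens); a lower number here means a stronger inhibitor, a higher number a weaker inhibitor.
Compound 2, `CCC1(CCCCN2CCN(c3cccc(Cl)c3)CC2)C(=O)Nc2c(Cl)cc(Cl)cc21`, gives 9.46 nM in this assay.
Compound 3, `CCC1(CCCCCN2CCN(c3cccc(Cl)c3)CC2)C(=O)Nc2ccccc21`, gives 1.45 nM in this assay.

Compound 1 holds the lowest number of the three in this assay. Its nearest neighbour is compound 3, whose number is higher by a margin beyond the usual scatter, and compound 2 lies furthest from it, again well beyond the scatter. Within the data shown here, none of these pairs differs in a single place, so no clean step between measured compounds is available.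

Compound 4, `CCC1(CCCCN2CCN(c3ccc(F)cc3)CC2)C(=O)Nc2ccccc21`, has not yet been measured in this assay. It differs from compound 1 by a single change: 4-fluorophenyl in place of 3-chlorophenyl on an amine nitrogen in a ring. Among the measured compounds shown here, no measured pair shows this change, so the expectation rests only on the shared core and the chain found in compound 1.

The step of a 7.3-fold higher number from compound 1 to compound 4 (0.86 log units; beyond the scatter) is expected to be upward and moderate in size, beyond the scatter. Compound 4 is therefore expected to give about 3 nM in this assay, with a range from 0.6 nM to 15 nM.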

Compound 4, inhibition constant: 0.43 nM
For compound 4 the middle estimate is 7.0-fold (0.84 log units) above the measured one; measured number below the stated range.
By their numbers in this assay, from the lowest: compounds 1 and 4 (each within the scatter of the next); then compound 3; then compound 2.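

In this assay, among these compounds, the change to 4-fluorophenyl in place of 3-chlorophenyl on an amine nitrogen in a ring gives a 1.0-fold higher number from compound 1 to compound 4 (0.02 log units; within the scatter) and is the first single-place comparison in this set. With the shared core and the chain of compound 1 held fixed, this site therefore accepts the exchange of these two aryl groups with no change that can be read in this assay. Nothing available explains why the two groups read alike.

The compounds shown leave open whether the same step would hold on the longer chain of compound 3 or on the dichloro core of compound 2. They also leave open how 4-chlorophenyl, 3-fluorophenyl or unsubstituted phenyl would read on this nitrogen, which would separate the identity of the halogen from its place on the ring.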